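From fluoro to trifluoromethoxy in a growth-inhibition series

The source may report more compounds than this note shows. Statements on the series, on what has been measured and on what is new or still open speak of the compounds shown alone.

Compound 1 `Cc1ccc2[nH]c(-c3ccc(-c4ccc(-c5ccc(N(C)C)cc5)cc4)cc3)nc2c1` gives 3230 nM
Compound 2 `Cc1ccc2[nH]c(-c3ccc(-c4ccc(-c5cccc(Cl)c5)cc4)cc3)nc2c1` gives 2510 nM
Compound 3 `Fc1ccc(-c2ccc(-c3ccc(-c4nc5ccccc5[nH]4)cc3)cc2)cc1` gives 35600 nM

All three numbers come from a functional assay on DWD cells (Homo sapiens) for inhibition, read by sulforhodamine B assay (on this read-out higher numbers stand for weaker inhibition of growth and lower numbers for stronger inhibition of growth), and compound 3 has the highest of them, with a gap to compound 1 and to compound 2 that lies beyond the usual scatter. Compound 4 `FC(F)(F)Oc1ccc(-c2ccc(-c3ccc(-c4nc5ccccc5[nH]4)cc3)cc2)cc1` is made from compound 3 by one change. That change trifluoromethoxy in place of fluoro on an aromatic carbon is trifluoromethoxy in place of fluoro on an aromatic carbon, para to a large group. Going by the values given here, only one measured step offers any guide, the swap of 3-chlorophenyl for 4-(dimethylamino)phenyl on an aromatic carbon. That step, a 1.3-fold lower number from compound 1 to compound 2 (0.11 log units; within the scatter), lies within the scatter. It is a loose guide, since it involves different groups and compounds 1 and 2 also differ from compound 3 elsewhere. A step beyond the scatter in this assay is therefore not expected. The estimated step is a 1.5-fold lower number from compound 3 to compound 4 (0.17 log units; within the scatter) and is expected to stay within the scatter. For compound 4 the expected value is 24000 nM with an estimated range of 7000 nM to 60000 nM on this thin evidence.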

Compound 4, concentration for 50% growth inhibition: 100000 nM
Beside the measured number, compound 4's estimate is 4.2-fold (0.62 log units) below it; measured number above the stated range.
By their numbers in this assay, from the lowest: compounds 2 and 1 (each within the scatter of the next); then compound 3; then compound 4.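

In this assay, trifluoromethoxy in place of fluoro gives a 2.8-fold higher number from compound 3 to compound 4 (0.45 log units; beyond the scatter), so growth inhibition weakens with this change. Going by these compounds alone, the one earlier step stayed within the scatter, whereas this one shows that the group on this aromatic carbon, para to a large group, can shift the result measurably. No measurement shown here explains why the number rises.

This single pair cannot separate the possible contributions of the entering group's additional heavy atoms, its oxygen or its three fluorines, since all of them arrive together. A methoxy group or an amine at the same position would help show which feature tracks with the weaker inhibition, and whether the trend continues beyond these two groups.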